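Indazole-series platelet assay notes: compound 4 from compound 3

The source may report more compounds than this note shows. Statements on the series, on what has been measured and on what is new or still open speak of the compounds shown alone.

Measured so far:
compound 1 `CCOC(=O)c1ccc(-c2nn(Cc3ccccc3Cl)c3ccccc23)cc1`: 230 nM
compound 2 `CCOC(=O)c1ccc(-c2nn(Cc3ccccc3F)c3ccccc23)cc1`: 110 nM
compound 3 `CCOC(=O)c1ccc(-c2nn(Cc3cccc(F)c3)c3ccccc23)cc1`: 270 nM

All three share one core and differ only in the group on the aromatic nitrogen. In a functional assay on cells (Platelet, Homo sapiens) for inhibition (on this read-out higher numbers stand for weaker inhibition and lower numbers for stronger inhibition), compound 3 gives the highest of the three numbers; its nearest neighbour is compound 1, with a 1.2-fold higher number from compound 1 to compound 3 (0.07 log units; within the scatter), and its furthest is compound 2, with a 2.5-fold higher number from compound 2 to compound 3 (0.39 log units; beyond the scatter). Within the data shown here, the one further measured step, a 2.1-fold lower number from compound 1 to compound 2 (0.32 log units; beyond the scatter), is modest as well.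

Compound 4 `CCOC(=O)c1ccc(-c2nn(-c3ccco3)c3ccccc23)cc1` carries the change (furan-2-yl in place of 3-fluorobenzyl on an aromatic nitrogen). Among the measured compounds shown here, no measured step bears on this change: the three measured steps move a halogen on the benzyl ring or shift its position, and each keeps a saturated chain carbon bound to the aromatic nitrogen, which compound 4 lacks. The measured steps give no guide to the direction; all of them were modest, so the expected step is not anchored in any of them.

Compound 4 is estimated at 600 nM in this assay, within a range of 150 nM to 2500 nM. That estimate means a step of a 2.2-fold higher number from compound 3 to compound 4 (0.35 log units; beyond the scatter), expected with wide uncertainty and leaning towards a higher number.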

Compound 4, half-maximal inhibitory concentration: 340 nM
Estimate against measurement, compound 4: 1.8-fold (0.25 log units) above; measured number inside the range.
By their numbers in this assay, from the lowest: compound 2; then compounds 1, 3 and 4 (each within the scatter of the next).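

In this assay the group on the aromatic nitrogen can change from 3-fluorobenzyl to furan-2-yl with no change beyond the scatter (a 1.3-fold higher number from compound 3 to compound 4 (0.10 log units; within the scatter)), and the same holds against the 2-chlorobenzyl group (a 1.5-fold higher number from compound 1 to compound 4 (0.17 log units; within the scatter)). The aromatic nitrogen therefore need not carry a saturated chain carbon or a six-membered aromatic ring for compound 4 to stay level with these two compounds, even with 5 heavy atoms entering for the 8 of 3-fluorobenzyl. Only the 2-fluorobenzyl group stands apart from furan-2-yl, and the gap is modest (a 3.1-fold higher number from compound 2 to compound 4 (0.49 log units; beyond the scatter)). No supporting data bear on the reason for this pattern.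

The compounds shown leave open whether the furan ring or the loss of the chain carbon matters more at this position, a question that a furan-2-ylmethyl group or a phenyl group on the aromatic nitrogen would separate. Also open, from the compounds shown here alone, is whether the same tolerance holds with a carboxylic acid in place of the ethyl ester, since all four compounds share that ester.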